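The source may hold more compounds than are shown below. What is called first, only, known or untested is meant among the compounds shown, and "the series" means these compounds.

Compound 1 `O=C1COCCN1c1ccc(C2CC(c3ccc([N+](=O)[O-])o3)=NO2)cc1F` was measured in an ADME assay on Caco-2 cells (Homo sapiens) for permeability, read by HPLC, with a stated time of 2 h (a lower number here means that the compound crosses the layer more slowly, a higher number that the compound crosses the layer faster), where compound 1 gives 154 nm/s. Compound 2 `CN1CCN(c2ccc(C3CC(c4ccc([N+](=O)[O-])o4)=NO3)cc2F)C(=O)C1` has also been measured, and in this assay compound 2 gives 270 nm/s. Among the measured compounds shown here, the one comparison that can be drawn between them, a 1.8-fold higher number from compound 1 to compound 2 (0.24 log units; within the scatter), comes from an exchange of 4-methyl-2-oxopiperazin-1-yl for 3-oxomorpholin-4-yl on an aromatic carbon. On the two numbers available, compound 1 and compound 2 therefore lie within the usual scatter of each other, and neither can be set apart from the other.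

Compound 3 `O=C1COCCN1c1ccc(C2CC(c3ccc([N+](=O)[O-])o3)=NO2)cc1` differs from compound 1 by hydrogen in place of fluoro on an aromatic carbon. For the measured compounds named here, no measured step touches this fluoro, so nothing bears on it directly; the only measured step changes a different group and stays within the scatter. Compound 3 is therefore expected to move from compound 1 by no more than a 1.1-fold higher number from compound 1 to compound 3 (0.04 log units; within the scatter), and its estimated value in this assay is 170 nm/s, with a range from 90 nm/s to 330 nm/s.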

Compound 3, apparent permeability in the Caco-2 assay: 126 nm/s
Compound 3: middle estimate off by 1.3-fold (0.13 log units), on the high side, and the stated range covers the measured number.
By their numbers in the Caco-2 assay, from the lowest: compounds 3, 1 and 2 (each within the scatter of the next, the first and the last beyond it).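

Among the compounds shown here, until now no measured step touched the fluoro, and in the Caco-2 assay the exchange for hydrogen gives a 1.2-fold lower number from compound 1 to compound 3 (0.09 log units; within the scatter), so at this place, ortho to a 3-oxomorpholin-4-yl group, the change cannot be told apart from the scatter in permeability. In a physicochemical assay for solubility, with a stated time of 18 h, at pH 7.4 (on this read-out lower numbers stand for lower solubility and higher numbers for higher solubility), compound 1 gives 12.6 ug/mL and compound 3 gives 25.9 ug/mL. The same exchange thus leaves its mark on solubility rather than permeability, though only just past the scatter: the measured solubility of compound 1, 12.6 ug/mL, and of compound 3, 25.9 ug/mL, a 2.1-fold higher number (0.31 log units; beyond the scatter)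

One pair cannot show whether this holds beyond the 3-oxomorpholin-4-yl series, for instance with the 4-methyl-2-oxopiperazin-1-yl group of compound 2. On these data alone, what chloro, methoxy or an amine at this same place would do in either read-out also remains open.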